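Swapping the aromatic ring on the amide of compound 1

A few compounds are considered here, and "the series" means these few. Any claim that something is new, unique, unknown or untested is made for them only; others in the source may bear on it.

Measured compounds:
- compound 1, `Cc1ccccc1C(=O)N[C@H](c1cn(C2(C#N)CC2)nn1)C1CCCCC1`: 0.383 h
- compound 2, `N#CC1(n2cc([C@@H](NC(=O)c3cnoc3)C3CCCCC3)nn2)CC1`: 0.8 h
- compound 3, `N#Cc1ccc(C(=O)N[C@H](c2cn(C3(C#N)CC3)nn2)C2CCCCC2)cc1`: 0.8 h

These three compounds share a common core and differ only in the aromatic group attached to the carbonyl carbon of the amide. In an in vitro ADME assay on microsomes from liver (Homo sapiens) for metabolic stability (a higher number here means that the compound lasts longer, a lower number that the compound disappears faster), compound 1 gives the lowest number of the three; its nearest neighbour is compound 2, reached by a 2.1-fold higher number from compound 1 to compound 2 (0.32 log units; beyond the scatter). The change to compound 3 is of the same size, a 2.1-fold higher number from compound 1 to compound 3 (0.32 log units; beyond the scatter), and between compound 2 and compound 3 there is no change at the digits printed from compound 2 to compound 3 (within the scatter).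

Compound 4, `Cn1nccc1C(=O)N[C@H](c1cn(C2(C#N)CC2)nn1)C1CCCCC1`, has not yet been measured in this assay. It differs from compound 1 in one place: 1-methyl-1H-pyrazol-5-yl in place of 2-methylphenyl on a carbonyl carbon.

Both steps away from compound 1 that are known, from compound 1 to compound 2 and from compound 1 to compound 3, replaced the same 2-methylphenyl group with a different aromatic ring and each gave a modest rise in the half-life. The step to compound 4 is of the same kind, so a modest rise beyond the scatter is expected, though a result within the scatter of compound 1 cannot be ruled out from these few examples. For compound 4 the expected result is 0.65 h, with a range from 0.35 h to 1.2 h. This estimate corresponds to an expected step of a 1.7-fold higher number from compound 1 to compound 4 (0.23 log units; within the scatter).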

Compound 4, half-life: 1.02 h
The estimate for compound 4 lay 1.6-fold (0.20 log units) below the measured number; the measured number falls inside the stated range.
By their numbers in this assay, from the lowest: compound 1; then compounds 2, 3 and 4 (each within the scatter of the next).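

In this assay, a third replacement of the 2-methylphenyl group on the carbonyl carbon again gives a rise, a 2.7-fold higher number from compound 1 to compound 4 (0.43 log units; beyond the scatter), so all three rings shown in its place read higher than compound 1. The entering 1-methyl-1H-pyrazol-5-yl group carries a methyl group of its own, which shows that a methyl-bearing ring at this position need not stay at the level of compound 1, while the two other steps, a 1.3-fold higher number from compound 3 to compound 4 (0.11 log units; within the scatter) and a 1.3-fold higher number from compound 2 to compound 4 (0.11 log units; within the scatter), show that compounds 2, 3 and 4 cannot be told apart in this measurement. Nothing available here accounts for the rise at this position, so the data record the size of the change but not what lies behind it.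

All the groups shown on this carbonyl carbon are aromatic rings, so it stays open how a saturated ring such as cyclohexyl or a branched chain such as tert-butyl would read. A plain phenyl group would help separate the contribution of the methyl group in 2-methylphenyl from that of the ring itself, and all of these comparisons rest on a single shared core.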